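Estimating compound 3 from two matched compounds

The source may hold more compounds than are shown below. What is called first, only, known or untested is meant among the compounds shown, and "the series" means these compounds.

Compound 1 `COc1ccc(N(C)c2nc(C)nc3ccccc23)cc1C(=O)OCCCC[Se]C#N`: 1080 nM
Compound 2 `COc1ccc(N(C)c2nc(C)nc3ccccc23)cc1C(=O)OCCCCCC[Se]C#N`: 1050 nM

Within the data shown here, in a functional assay on LoVo cells (Homo sapiens) for inhibition, read by MTT assay, with a stated time of 48 h (on this read-out lower numbers stand for stronger inhibition and higher numbers for weaker inhibition), compound 2 gives 1050 nM and stands within the scatter of compound 1 on the only two numbers available, so neither can be ranked above the other. Compound 3 `COc1ccc(N(C)c2nc(C)nc3ccccc23)cc1C(=O)OCCCCC[Se]C#N` has not yet been measured. Its structure departs from that of compound 2 as follows: a group of 3 heavy atoms (1 carbon, 1 nitrogen, 1 selenium; no ring) in place of a group of 4 heavy atoms (2 carbon, 1 nitrogen, 1 selenium; no ring), on a saturated chain carbon, five bonds along the chain from an oxygen next to a carbonyl group. Among the measured compounds shown here, only one measured step bears on this change. That step, a 1.0-fold lower number from compound 1 to compound 2 (0.01 log units; within the scatter), alters the same chain, swapping a group of 5 heavy atoms for a group of 3 heavy atoms, and it stays within the scatter. The new change is of the same kind, so no step beyond the scatter is expected. The estimate amounts to a 1.0-fold higher number from compound 2 to compound 3 (0.00 log units; within the scatter) and this expected step is within the scatter. In this assay the expected value for compound 3 is 1060 nM with 570 nM to 1950 nM as its estimated range.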

Compound 3, half-maximal inhibitory concentration: 714 nM
For compound 3 the middle estimate is 1.5-fold (0.17 log units) above the measured one; measured number inside the range.
By their numbers in this assay, from the lowest: compounds 3, 2 and 1 (each within the scatter of the next).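

In this assay, the change on the saturated chain carbon five bonds along the chain from an oxygen next to a carbonyl group gives a 1.5-fold lower number from compound 2 to compound 3 (0.17 log units; within the scatter), and the change four bonds along the chain gives a 1.5-fold lower number from compound 1 to compound 3 (0.18 log units; within the scatter). With a third chain length now measured, both new steps stay within the scatter, just as the earlier step did, so compounds 1, 2 and 3 still cannot be ranked and none of these chain lengths stands apart from the others. Nothing shown offers an explanation for these numbers. The compounds shown leave open whether a much longer chain, or a much shorter one, would carry the number beyond the scatter. They also leave open what a sulfur atom in place of the selenium would do on this same chain.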